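The source may report more compounds than this note shows. Statements on the series, on what has been measured and on what is new or still open speak of the compounds shown alone.

Series notes. Among the compounds with values here, compound 1 `CC(CCc1ccc(OCc2ccc3ccccc3n2)cc1)Cc1nnn[nH]1` gives 25 nM in an assay on membranes from lung (Cavia porcellus) for binding affinity to cysteinyl leukotriene receptor (Homo sapiens) (on this read-out lower numbers stand for stronger inhibition and higher numbers for weaker inhibition), and compound 3 `CCCC(CCC(=O)O)Cc1ccc(OCc2ccc3ccccc3n2)cc1` gives 21 nM in this assay; the single measured step, a 1.2-fold lower number from compound 1 to compound 3 (0.08 log units; within the scatter), shows that the tetrazole and the carboxylic acid on that side chain come out alike. Compound 2 `CC(CCCC(=O)O)c1cccc(OCc2ccc3ccccc3n2)c1` gives 90 nM in this assay, the highest of the three numbers and beyond the scatter from both compound 1 and compound 3. Compound 4 `c1cc(OCCCc2nnn[nH]2)cc(OCc2ccc3ccccc3n2)c1` is the next step: 3-(1H-tetrazol-5-yl)propoxy in place of 4-carboxy-1-methylbutyl on an aromatic carbon. Within the data shown here, the only measured step bearing on this exchange is a 1.2-fold lower number from compound 1 to compound 3 (0.08 log units; within the scatter); no measured step covers the loss of the methyl branch or the added ether oxygen. The step is therefore expected to be small, a 1.4-fold lower number from compound 2 to compound 4 (0.14 log units; within the scatter), and not beyond the scatter. The estimate for compound 4 is 65 nM, with a range from 20 nM to 220 nM.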

Compound 4, inhibition constant: 42 nM
The estimate for compound 4 lay 1.5-fold (0.19 log units) above the measured number, within the range that was stated.
By their numbers in this assay, from the lowest: compounds 3, 1 and 4 (each within the scatter of the next); then compound 2.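

Exchanging 4-carboxy-1-methylbutyl for 3-(1H-tetrazol-5-yl)propoxy on this aromatic carbon gives a 2.1-fold lower number from compound 2 to compound 4 (0.33 log units; beyond the scatter) in this assay and so moves the number beyond the scatter, unlike the earlier exchange between the two acidic-named side chains on the other core, a 1.2-fold lower number from compound 1 to compound 3 (0.08 log units; within the scatter). The change alters the end group, the branch and the linking oxygen at once, so the step belongs to no single one of them. Nothing measured accounts for this step.

Open, on these data alone, is whether a carboxylic acid on the same propoxy chain would match the tetrazole here. As far as these compounds go, a longer chain at this position is equally open.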